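A few compounds are considered here, and "the series" means these few. Any claim that something is new, unique, unknown or untested is made for them only; others in the source may bear on it.

Measured so far in a functional assay on A2780 cells (Homo sapiens) for cytotoxicity, read by MTT assay, with a stated time of 24 h; a lower number here means a stronger inhibitor, a higher number a weaker inhibitor:
- Compound 1 `C[C@H]1O[C@]1(C)C(=O)C[C@@H]1[C@@]2(C)[C@@H](O)CCC(C)(C)[C@]2(O)CC[C@@]1(C)O`: > 10000 nM
- Compound 2 `C[C@H]1O[C@]1(C)C(=O)C[C@H]1[C@](C)(O)CC[C@@]2(O)C(C)(C)CCC[C@]12C`: > 10000 nM
- Compound 3 `C/C=C(\C)C(=O)C[C@]1(O)[C@@]2(C)CCCC(C)(C)[C@]2(O)CC[C@@]1(C)O`: > 10000 nM

Compound 2 stands at > 10000 nM, which is a limit of the assay and not a number. The other measured compounds offer no number either: the limit of > 10000 nM in this assay, at which 3 of the 3 values shown sit.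

Compound 4 `C/C=C(\C)C(=O)C[C@H]1[C@](C)(O)CC[C@@]2(O)C(C)(C)CCC[C@]12C` differs from compound 2 by one change: 1-methylprop-1-en-1-yl in place of 2,3-dimethyloxiran-2-yl on a carbonyl carbon. Here 1-methylprop-1-en-1-yl replaces 2,3-dimethyloxiran-2-yl on a carbonyl carbon, so the three-membered ring goes and a double bond outside any ring enters.

For the measured compounds named here, the only measured step, a step that the two limits leave unreadable from compound 1 to compound 2, concerns hydrogen in place of hydroxy on a saturated ring carbon, not this group, and it has no size to carry over. With no readable step to build on, the expectation in this assay stays close to the limit, with no firm direction. The estimated step is a step that the limit leaves unreadable from compound 2 to compound 4. For compound 4 the expected value is 20000 nM, with an estimated range from 8000 nM to 50000 nM, and the assay will most likely report only a limit again.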

Compound 4, half-maximal inhibitory concentration: > 10000 nM
Compound 4: a limit, no number; the forecaster's own chance of this, stated with the estimate: 85%; the middle value does not contradict the limit.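

Compound 2 and compound 4 both sit at a limit rather than a number, so no step can be read for 1-methylprop-1-en-1-yl in place of 2,3-dimethyloxiran-2-yl. How strong any of these compounds really is, and whether any of these changes matters, stays open: the limit of > 10000 nM in this assay, at which 4 of the 4 values shown sit.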